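Swapping Phenyl for Cyclohexyl on a Ring Amine Nitrogen

A few compounds are considered here, and "the series" means these few. Any claim that something is new, unique, unknown or untested is made for them only; others in the source may bear on it.

Measured so far in a functional assay on HeLa cells (Homo sapiens) for antiproliferative activity, read by CCK-8 assay, with a stated time of 72 h, tested at 8 uM; a higher number here means a stronger effect of the compound at the concentration tested, a lower number a weaker effect:
compound 1 `Nc1ccccc1NC(=O)c1ccc(CSC(=S)N2CCN(C(c3ccccc3)c3ccccc3)CC2)cc1`: 13.8%
compound 2 `Nc1ccccc1NC(=O)c1ccc(CSC(=S)N2CCN(c3ccccc3)CC2)cc1`: 73.1%
compound 3 `Nc1ccccc1NC(=O)c1ccc(CSC(=S)N2CCCc3ccccc32)cc1`: 35.7%

Compound 2 gives the highest of the three numbers in this assay. Its nearest neighbour is compound 3, whose number lies lower by a margin beyond the scatter, and compound 1 lies lower still, again beyond the scatter.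

Compound 4 `Nc1ccccc1NC(=O)c1ccc(CSC(=S)N2CCN(C3CCCCC3)CC2)cc1` differs from compound 2 in one place: cyclohexyl in place of phenyl on an amine nitrogen in a ring. For the measured compounds named here, no measured pair shows this change, so its effect is open. The step expected from compound 2 to compound 4 is a number 21.1 percentage points lower from compound 2 to compound 4 (beyond the scatter), a moderate fall that is uncertain in size. Compound 4 is therefore estimated at 52% in this assay, within a range from 22% to 78%.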

Compound 4, a percentage reported as inhibition, at one concentration (the size of the read-out at that concentration, not a potency): 76.1%
The estimate for compound 4 lay 24.1 percentage points below the measured number, and the stated range covers the measured number.
By their numbers in this assay, from the lowest: compound 1; then compound 3; then compounds 2 and 4 (each within the scatter of the next).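

In this assay, cyclohexyl in place of phenyl on the amine nitrogen in the ring gives a number 3 percentage points higher from compound 2 to compound 4 (within the scatter) and so shows that an aromatic ring of carbon is not required at this place for the effect at the concentration tested. The non-aromatic ring of the same size reads alike. No available evidence explains this likeness. The compounds shown leave open whether a smaller group such as methyl would hold the number at this nitrogen, and whether a cyclohexyl ring carrying a carboxylic acid or an amine would do so.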